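Side-chain exchange on the shared core: dimethylamino for sulfanyl

The source may hold more compounds than are shown below. What is called first, only, known or untested is meant among the compounds shown, and "the series" means these compounds.

Compound 1 (`N=c1sc2cc(OC(F)(F)F)ccc2n1CC(N)=O`) gives 7 mg/kg
Compound 2 (`N=c1sc2cc(OC(F)(F)F)ccc2n1CCS`) gives 2 mg/kg

Both values come from a functional assay on the whole organism with Rattus norvegicus as the target (a lower number here means that less compound is needed, a higher number that more compound is needed for the effect), and compound 2 holds the lower of the two numbers. Compound 3 (`CN(C)CCn1c(=N)sc2cc(OC(F)(F)F)ccc21`) has dimethylamino in place of sulfanyl on a saturated chain carbon, two bonds along the chain from an aromatic nitrogen. Among the measured compounds shown here, no measured step covers this exchange directly. For the measured compounds named here, the only guide is the modest step of a 3.5-fold lower number from compound 1 to compound 2 (0.54 log units; beyond the scatter), which is beyond the scatter and also changes the group on this chain. A step of similar modest size is therefore expected, towards a higher number, since compound 2 at 2 mg/kg stands lowest so far, though the direction is uncertain. The expected change is a 2.5-fold higher number from compound 2 to compound 3 (0.40 log units; beyond the scatter). Compound 3 is estimated at 5 mg/kg, with an expected range of 2 mg/kg to 12 mg/kg.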

Compound 3, dose for half-maximal effect: 2.3 mg/kg
Estimate against measurement, compound 3: 2.2-fold (0.34 log units) above, and the stated range covers the measured number.
By their numbers in this assay, from the lowest: compounds 2 and 3 (each within the scatter of the next); then compound 1.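

In this assay, dimethylamino in place of sulfanyl gives a 1.2-fold higher number from compound 2 to compound 3 (0.06 log units; within the scatter) and so shows that this chain carbon accepts a group of 3 heavy atoms with 0 hydrogen-bond donors in place of one with 1 hydrogen-bond donor, without a change beyond the scatter. The carbamoyl compound now differs from two replacements rather than one: (dimethylamino)methyl in place of carbamoyl gives a 3.0-fold lower number from compound 1 to compound 3 (0.48 log units; beyond the scatter) and stands as a second step beyond the scatter, alongside a 3.5-fold lower number from compound 1 to compound 2 (0.54 log units; beyond the scatter) in the same direction. No evidence is available that bears on this result.

On these data alone, whether a longer chain, or a cyclic amine such as morpholine on this chain carbon, stays in the range of compound 2 and compound 3 remains open. So does whether a carboxylic acid there falls with carbamoyl.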